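Notes on a bicyclic aryl amine series: compound 3 to compound 4

The compounds below may be only part of what the source reports. "The series", "measured", "known", "first", "only" and "open" are said of these compounds alone.

Measured so far:
compound 1, `COc1cc(OC)n2cc(-c3ccc(N)cc3)nc2n1` — a limit only, > 100000 nM
compound 2, `Cc1ccc2nc(-c3ccc(NCc4ccccc4)cc3)cn2c1` — 56100 nM
compound 3, `Cc1ccc2nc(-c3ccc(N(Cc4ccccc4)Cc4ccccc4)cc3)cn2c1` — 60000 nM

In a functional assay on A549 cells (Homo sapiens) for antiproliferative activity, read by MTT assay, with a stated time of 72 h (a lower number here means a stronger inhibitor of growth, a higher number a weaker inhibitor of growth), compound 1 is reported only as a limit, > 100000 nM. Compound 2 gives 56100 nM in this assay, and compound 3 gives 60000 nM. Among the compounds with values here, the one step measured so far, a 1.1-fold higher number from compound 2 to compound 3 (0.03 log units; within the scatter), changes the substitution on the aniline nitrogen and not the bicyclic part. Compound 3 therefore has the highest of the two numbers, with compound 2 nearest and within the scatter; the third value shown is a limit.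

Compound 4, `Cc1ccn2cc(-c3ccc(N(Cc4ccccc4)Cc4ccccc4)cc3)nc2c1`, differs from compound 3 by a group of 10 heavy atoms (8 carbon, 2 nitrogen; one five-membered aromatic ring with 2 hetero atoms, one six-membered aromatic ring with 1 hetero atom) in place of a group of 10 heavy atoms (8 carbon, 2 nitrogen; one five-membered aromatic ring with 2 hetero atoms, one six-membered aromatic ring with 1 hetero atom), on an aromatic carbon. Within the data shown here, no measured step touches this part of the molecule; the step of a 1.1-fold higher number from compound 2 to compound 3 (0.03 log units; within the scatter) lies elsewhere and is within the scatter, so it gives no direction to borrow. No step beyond the scatter is therefore expected. For compound 4 the expected value in this assay is 60000 nM, within 20000 nM to 150000 nM, meaning an expected no change at the digits printed from compound 3 to compound 4 (within the scatter). The upper end of that range approaches (the limit of > 100000 nM in this assay, at which 1 of the 3 values shown sits), so a limit rather than a number is a real possibility.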

Compound 4, concentration for 50% growth inhibition: 17200 nM
For compound 4 the middle estimate is 3.5-fold (0.54 log units) above the measured one; measured number outside the range, below it.
By their numbers in this assay, from the lowest: compound 4; then compounds 2 and 3 (each within the scatter of the next). At a limit, above all of these: compound 1.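

With a 3.5-fold lower number from compound 3 to compound 4 (0.54 log units; beyond the scatter) in this assay the series shows its first step beyond the scatter, at the bicyclic group on the aromatic carbon para to a large group. The leaving and entering groups have the same atoms, ring types, hydrogen-bond donors and acceptors, and no net charge, yet the way those atoms are joined still moves the number. The only earlier step, a 1.1-fold higher number from compound 2 to compound 3 (0.03 log units; within the scatter) on the aniline nitrogen, stayed within the scatter, so among these compounds only the bicyclic change gives a readable difference.

On these data alone, whether the same change holds with one benzyl on the nitrogen, or with a morpholine or a carboxylic acid in place of the dibenzylamino group, stays open. Nothing measured here bears on the reason for this step.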